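Methoxy in Place of Nitro on a Carbamate Scaffold

A few compounds are considered here, and "the series" means these few. Any claim that something is new, unique, unknown or untested is made for them only; others in the source may bear on it.

Compound 1 `CCCCNC(=O)Oc1ccc(C(=O)OC)cc1`: 35%
Compound 2 `CCCCNC(=O)Oc1ccc([N+](=O)[O-])cc1`: 16%
Compound 3 `O=C(NC1CCCCC1)Oc1ccc([N+](=O)[O-])cc1`: 25%

In an assay on cell membranes (strain Wistar) for inhibition of Fatty-acid amide hydrolase 1 (Rattus norvegicus), read by scintillation counting, tested at 0.1 uM (on this read-out higher numbers stand for more inhibition at the one concentration tested (going by the name of the read-out) and lower numbers for less inhibition), compound 2 gives 16%, the smallest of the three numbers. Compound 3 sits close by, the step being a number 9 percentage points higher from compound 2 to compound 3 (within the scatter), so the two cannot be ordered. Compound 1 stands further off: the step of a number 19 percentage points lower from compound 1 to compound 2 (beyond the scatter) is beyond the scatter.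

Compound 4 `CCCCNC(=O)Oc1ccc(OC)cc1` has not been measured. Its change from compound 2 is methoxy in place of nitro on an aromatic carbon. Among the measured compounds shown here, only one measured step touches the same place: the step of a number 19 percentage points lower from compound 1 to compound 2 (beyond the scatter), where a nitro group entered. Taking the nitro group out again, now for a methoxy group, is the reverse kind of change, though methoxy is not methoxycarbonyl, so the measured step is a rough guide only. Compound 4 is therefore expected to move up modestly, with a number 14 percentage points higher from compound 2 to compound 4 (beyond the scatter). The estimate for compound 4 is 30%, with a range from 12% to 50%.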

Compound 4, a percentage reported as inhibition, at one concentration (the size of the read-out at that concentration, not a potency): 5%
For compound 4 the middle estimate is 25 percentage points above the measured one; measured number outside the range, below it.
By their numbers in this assay, from the lowest: compound 4; then compounds 2, 3 and 1 (each within the scatter of the next, the first and the last beyond it).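

In this assay the methoxy group does not lift the number on the butyl carbamate but lowers it, with a number 11 percentage points lower from compound 2 to compound 4 (beyond the scatter), so taking the nitro group out does not by itself bring back what methoxycarbonyl gives. Against methoxycarbonyl the change is larger, with a number 30 percentage points lower from compound 1 to compound 4 (beyond the scatter), and on this butyl carbamate the three groups at this position now separate beyond the scatter, in the falling order methoxycarbonyl, nitro, methoxy. Nothing available here accounts for that order.

As far as these compounds go, whether the same order holds with the cyclohexyl group of compound 3 on the nitrogen remains open. So does where an amine, a carboxylic acid or a longer ester at this position would fall in that order.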